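A few compounds are considered here, and "the series" means these few. Any claim that something is new, unique, unknown or untested is made for them only; others in the source may bear on it.

Compound 2 `C=C1C(=O)[C@]23C[C@@]1(O)CC[C@H]2c1ccc(OS(=O)(=O)c2ccc(C)cc2)c(C)c1[C@@H]3Cn1cc(-c2ccc(F)cc2)nn1` carries a (4-methylphenyl)sulfonyl group on an oxygen on an aromatic ring of the shared core. Compound 1 `C=C1C(=O)[C@]23C[C@@]1(O)CC[C@H]2c1ccc(O)c(C)c1[C@@H]3Cn1cc(-c2ccc(F)cc2)nn1` has a hydrogen there instead; in a functional assay on SMMC-7721 cells (Homo sapiens) for cytotoxicity, read by MTT assay, with a stated time of 4 days (on this read-out lower numbers stand for stronger inhibition and higher numbers for weaker inhibition), compound 1 gives 850 nM and compound 2 gives 4280 nM, so that a 5.0-fold higher number from compound 1 to compound 2 (0.70 log units; beyond the scatter). Compound 3 `C=C1C[C@]23C[C@@]1(O)CC[C@H]2c1cc(Br)c(O)c(C)c1[C@@H]3Cn1cc(-c2ccccc2)nn1` differs from both in several places, and in this assay compound 3 reaches only the limit > 20000 nM. Of the two numbers shown, compound 2 has the higher one. Compound 4 `C=C1C(=O)[C@]23C[C@@]1(O)CC[C@H]2c1ccc(OS(=O)(=O)c2ccc(C)cc2)c(C)c1[C@@H]3Cn1cc(-c2ccc(OC)cc2)nn1` differs from compound 2 by methoxy in place of fluoro on an aromatic carbon. Among the compounds with values here, the single measured step concerns the sulfonyl substitution, not the ring where this change sits, so it offers no direct guide, and no step beyond the scatter is expected in this assay. Compound 4 is therefore estimated at 4300 nM, within 1500 nM to 12000 nM, meaning a 1.0-fold higher number from compound 2 to compound 4 (0.00 log units; within the scatter).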

Compound 4, half-maximal inhibitory concentration: 1720 nM
For compound 4 the middle estimate is 2.5-fold (0.40 log units) above the measured one; the measured number falls inside the stated range.
By their numbers in this assay, from the lowest: compound 1; then compound 4; then compound 2. At a limit, above all of these: compound 3.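

The ring carrying the fluoro group is not a silent place: in this assay, going from 4-fluorophenyl to 4-methoxyphenyl gives a 2.5-fold lower number from compound 2 to compound 4 (0.40 log units; beyond the scatter). This position, untouched by the earlier step, therefore responds to a change of group, here toward stronger inhibition, although the step is modest. No measurement shown accounts for this step.

From the compounds shown here alone, it remains open whether an amine, a carboxylic acid or a longer chain at this place would lower the number further. Going by these compounds, it is also open whether methoxy gives a similar step with the free hydroxyl of compound 1 in place of the sulfonyl group.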